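The source may report more compounds than this note shows. Statements on the series, on what has been measured and on what is new or still open speak of the compounds shown alone.

In a functional assay on MCF7 cells (Homo sapiens) for antiproliferative activity, read by MTT assay, with a stated time of 48 h (a higher number here means a weaker inhibitor, a lower number a stronger inhibitor), compound 1 (`O=C(NS(=O)(=O)c1ccccc1)c1cncc(Br)c1`) gives 12900 nM and compound 2 (`O=C(NS(=O)(=O)c1ccc(F)cc1)c1ccc(Cl)nc1`) gives 16800 nM as its half-maximal inhibitory concentration. Within the data shown here, these two numbers lie within the usual scatter of each other, so compound 2 stands level with the only other compound measured so far. Compound 3 (`O=C(NS(=O)(=O)c1ccc(Cl)cc1)c1ccc(Cl)nc1`) differs from compound 2 in one place, with chloro in place of fluoro on an aromatic carbon. The swap reads chloro in place of fluoro on an aromatic carbon and nothing else in the molecule changes. Among the measured compounds shown here, no pair of measured compounds shows what such a swap does, so the data offer no direct guide. With compound 2 at 16800 nM as the anchor, no shift beyond the scatter is expected, with at most a slight lean toward a lower number. The estimated step of a 1.2-fold lower number from compound 2 to compound 3 (0.08 log units; within the scatter) stays within that scatter. Compound 3 is expected to give about 14000 nM with a likely range from 6500 nM to 29000 nM in this assay once it is measured.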

Compound 3, half-maximal inhibitory concentration: 8070 nM
The estimate for compound 3 lay 1.7-fold (0.24 log units) above the measured number; measured number inside the range.
By their numbers in this assay, from the lowest: compounds 3, 1 and 2 (each within the scatter of the next, the first and the last beyond it).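

In this assay, chloro in place of fluoro on an aromatic carbon, para to a large group, gives a 2.1-fold lower number from compound 2 to compound 3 (0.32 log units; beyond the scatter), a modest step. Among these compounds, this is the first sign that the number responds to the group at this position: exchanging one halogen for another, with the rest of the molecule unchanged, is enough to move it past the usual scatter. This single pair gives no rule for other groups, and no measurement here accounts for the shift.

On these data alone, it remains open whether a different kind of group at this position, such as a methoxy group, an amine or a carboxylic acid, would move the number further, and in which direction. Also open, as far as these compounds go, is whether the same swap would have a similar effect on the core of compound 1.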